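A few compounds are considered here, and "the series" means these few. Any claim that something is new, unique, unknown or untested is made for them only; others in the source may bear on it.

Measured compounds:

Compound 1, `COc1ccc(C2CC(c3ccccc3)=NN2C2=NC(=O)/C(=C3\C(=O)Nc4ccc(Br)cc43)S2)cc1`, in a functional assay on cells (Cancer cell lines, Homo sapiens) for cytotoxicity, read by sulforhodamine B assay, with a stated time of 48 h (on this read-out lower numbers stand for stronger inhibition of growth and higher numbers for weaker inhibition of growth), gives 240 nM.
Compound 2, `COc1ccc(C2=NN(C3=NC(=O)/C(=C4\C(=O)Nc5ccc(Br)cc54)S3)C(c3ccc(OC)cc3)C2)cc1`, gives 270 nM.
Compound 3, `O=C1N=C(N2N=C(c3ccccc3)CC2c2ccc(Cl)cc2)S/C1=C1/C(=O)Nc2ccccc21`, gives 250 nM.

The three measured values lie close together, and none of the gaps between them exceeds the scatter of this assay.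

Compound 1 and compound 2 share a core and differ by methoxy in place of hydrogen on an aromatic carbon. That change produced a 1.1-fold higher number from compound 1 to compound 2 (0.05 log units; within the scatter), so on this pair the methoxy group neither helped nor hurt in a way that could be resolved.

Compound 3 and compound 1 differ in more than one place; the difference between the two cores is not broken down here.

Compound 4, `COc1ccc(C2=NN(C3=NC(=O)/C(=C4\C(=O)Nc5ccccc54)S3)C(c3ccc(Cl)cc3)C2)cc1`, is not yet measured. It differs from compound 3 by methoxy in place of hydrogen on an aromatic carbon. The place description is word for word the same as for the change from compound 1 to compound 2, so this is the same change made on a second core.

For compound 4 the expectation rests on that earlier pair: because the step of a 1.1-fold higher number from compound 1 to compound 2 (0.05 log units; within the scatter) was within the scatter, the step from compound 3 to compound 4 is expected to be a 1.1-fold higher number from compound 3 to compound 4 (0.03 log units; within the scatter). Compound 4 is therefore estimated at 270 nM, with a range from 150 nM to 480 nM.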

Compound 4, concentration for 50% growth inhibition: 100000 nM
Beside the measured number, compound 4's estimate is 370-fold (2.57 log units) below it; measured number above the stated range.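

On the core of compound 3, methoxy in place of hydrogen on an aromatic carbon gives a 400-fold higher number from compound 3 to compound 4 (2.60 log units; beyond the scatter) in this assay, a large loss of growth inhibition. The result of this change on one core therefore does not predict its result on the other, and the silent step on the core of compound 1 cannot be taken as a general tolerance for methoxy in this series: the same change on two cores in this assay, a 1.1-fold higher number (0.05 log units; within the scatter) from compound 1 to compound 2 and a 400-fold higher number (2.60 log units; beyond the scatter) from compound 3 to compound 4, 360-fold (2.55 log units) apart, beyond the scatter of two such steps. Within the data shown here, with only two pairs, and with cores that differ in more than one place, this does not show which core difference makes the change so costly on one core and not on the other, nor does it give a rule for any further core.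

On these data alone, it remains open which of the core differences decides the outcome, since each core is represented by a single pair. Also open, as far as these compounds go, is how an ethoxy group, a hydroxyl or an amine on the same aromatic carbon would read on either core.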